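A few compounds are considered here, and "the series" means these few. Any claim that something is new, unique, unknown or untested is made for them only; others in the source may bear on it.

Compound 1 `Nc1scc(-c2ccccc2)c1C(=O)c1ccc(Cl)cc1` gives 64% in a functional assay on CHO cells for agonist activity at adenosine receptor A1 (Homo sapiens), read by fluorescence and ERK phosphorylation, with stated times of 30 min and 1.5 h, tested at 10 uM; a higher number here means a stronger effect of the compound at the concentration tested, a lower number a weaker effect; compound 2 `Nc1scc(-c2ccccc2F)c1C(=O)c1ccc(Cl)cc1` gives 87%; compound 3 `Nc1scc(-c2ccc(Cl)cc2)c1C(=O)c1ccc(Cl)cc1` gives 50%.

Compound 3 stands lowest of the three numbers: the step of a number 14 percentage points lower from compound 1 to compound 3 (beyond the scatter) separates it from compound 1, and the step of a number 37 percentage points lower from compound 2 to compound 3 (beyond the scatter) from compound 2. Compound 4 `Nc1scc(-c2ccc(Br)cc2)c1C(=O)c1ccc(Cl)cc1` differs from compound 3 by bromo in place of chloro on an aromatic carbon. Going by the values given here, the only measured step touching this position is a number 14 percentage points lower from compound 1 to compound 3 (beyond the scatter), where chloro replaced hydrogen, a modest fall. Among the compounds with values here, no measured step shows bromo in place of chloro, so the exchange of one halogen for another at the same place is expected to give little beyond the scatter. Compound 4 is therefore estimated at 46% in this assay, between 28% and 64%, which corresponds to an expected step of a number 4 percentage points lower from compound 3 to compound 4 (within the scatter).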

Compound 4, a percentage reported as activity, at one concentration (the size of the read-out at that concentration, not a potency): 46%
Compound 4: the middle estimate sits on the measured number at the digits printed, and the stated range covers the measured number.
By their numbers in this assay, from the lowest: compounds 4 and 3 (each within the scatter of the next); then compound 1; then compound 2.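

In this assay the exchange of chloro for bromo gives a number 4 percentage points lower from compound 3 to compound 4 (within the scatter) so the two halogens cannot be told apart at this place. Bromo in place of hydrogen gives a number 18 percentage points lower from compound 1 to compound 4 (beyond the scatter) and so repeats the fall seen with chloro, while 4-bromophenyl in place of 2-fluorophenyl gives a number 41 percentage points lower from compound 2 to compound 4 (beyond the scatter) and is a large step, as it was for compound 3. No measurement shown here explains these numbers.

Going by these compounds, what an amine or a methoxy group on this same carbon would do remains open. So does whether fluoro, placed para to a large group, would behave like chloro and bromo or like the fluoro of compound 2.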